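A few compounds are considered here, and "the series" means these few. Any claim that something is new, unique, unknown or untested is made for them only; others in the source may bear on it.

Of the compounds shown here, two measured so far share one core and differ in what hangs from its amine nitrogen. Compound 1 `Cc1ccc(C(=O)NC(=N)Nc2ccc(C(C)C)cc2)cc1` joins the nitrogen straight to an aromatic ring, and in a functional assay on the whole organism for inhibition, with Mus musculus as the target, at a dose of 20 mg/kg by the intraperitoneal route (on this read-out lower numbers stand for less inhibition and higher numbers for more inhibition at the one dose given (going by the name of the read-out)), compound 1 gives 30%. Compound 2 `Cc1ccc(C(=O)NC(=N)NCCCCc2ccccc2)cc1` puts a saturated chain between the nitrogen and the ring, and in this assay compound 2 gives 75%, the higher of the two numbers, with the gap to compound 1 beyond the usual scatter. Compound 3 `Cc1ccc(C(=O)NC(=N)NCCCCCc2ccccc2)cc1` is not yet measured and differs from compound 2 by benzyl in place of phenyl on a saturated chain carbon, four bonds along the chain from an amine nitrogen, so the chain simply grows. Among the measured compounds shown here, no matched pair of this kind has been measured, so the step of a number 7 percentage points lower from compound 2 to compound 3 (within the scatter) is expected to be small, most likely within the scatter, with a slight lean downward. Compound 3 is therefore estimated at 68% in this assay, somewhere between 45% and 90%.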

Compound 3, a percentage reported as inhibition, in the whole organism at one dose (the size of the read-out at that dose, not a potency): 7%
Estimate against measurement, compound 3: 61 percentage points above; the measured number lies below the stated range.
By their numbers in this assay, from the lowest: compound 3; then compound 1; then compound 2.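

Among the compounds shown here, this is the first pair in the set that differs in one place only, and it shows that the outcome in this assay is highly sensitive at this spot, on a saturated chain carbon, four bonds along the chain from an amine nitrogen. Benzyl in place of phenyl brings a number 68 percentage points lower from compound 2 to compound 3 (beyond the scatter), although the two groups differ only in heavy atoms, 7 carbon against 6, and match in their aromatic ring, hydrogen-bond donors, hydrogen-bond acceptors and net charge. Nothing here accounts for this drop.

The compounds shown leave open whether the low number persists with a longer chain or changes with a shorter one. They also leave open how an amine or a carboxylic acid on the chain would read in this assay.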